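Dithiocarbamate-Triazole Series: Estimating a Dichlorobenzyl Analogue

The source may hold more compounds than are shown below. What is called first, only, known or untested is meant among the compounds shown, and "the series" means these compounds.

Measured compounds:
- compound 1, `CC(C)(C)OC(=O)N1CCN(C(=S)SCc2cn(-c3ccccc3F)nn2)CC1`: 119000 nM
- compound 2, `CC(C)(C)OC(=O)N1CCN(C(=S)SCc2cn(Cc3cc(=O)oc4cc(O)ccc34)nn2)CC1`: 4960 nM
- compound 3, `S=C(SCc1cn(Cc2ccccc2Cl)nn1)N1CCNCC1`: 45200 nM

In a functional assay on MGC-803 cells (Homo sapiens) for inhibition, read by MTT assay, with a stated time of 72 h (on this read-out higher numbers stand for weaker inhibition and lower numbers for stronger inhibition), compound 1 gives 119000 nM, the highest number of the three, which on this read-out means the weakest inhibition. Compound 3 sits nearest to it and its number is lower by a margin beyond the scatter; compound 2 stands furthest away, with a much lower number. Compound 4, `CC(C)(C)OC(=O)N1CCN(C(=S)SCc2cn(Cc3ccc(Cl)c(Cl)c3)nn2)CC1`, has not been measured. It differs from compound 1 in one place: 3,4-dichlorobenzyl in place of 2-fluorophenyl on an aromatic nitrogen.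

Within the data shown here, no measured pair shows this exact change. Still, the two compounds with a benzyl-type group on that nitrogen, compound 2 and compound 3, both give lower numbers than compound 1, even though compound 3 also lacks the protecting group on its piperazine. A step downward, beyond the scatter, therefore seems the more likely outcome in this assay, while the size is uncertain.

Compound 4 is expected to give 30000 nM, within a range of 8000 nM to 100000 nM, which would mean an estimated step of a 4.0-fold lower number from compound 1 to compound 4 (0.60 log units; beyond the scatter).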

Compound 4, half-maximal inhibitory concentration: 33700 nM
Beside the measured number, compound 4's estimate is 1.1-fold (0.05 log units) below it; the measured number falls inside the stated range.
By their numbers in this assay, from the lowest: compound 2; then compounds 4 and 3 (each within the scatter of the next); then compound 1.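

Placing 3,4-dichlorobenzyl where 2-fluorophenyl stood on the aromatic nitrogen gives, in this assay, a 3.5-fold lower number from compound 1 to compound 4 (0.55 log units; beyond the scatter) and leaves the rest of the molecule untouched, so a change at this position alone can move the number beyond the usual scatter. Among these compounds, none of the earlier compounds provided a step of this kind, although the step is modest and the swap changes two things at once: the halogens differ, and the new group has a carbon between its ring and the aromatic nitrogen, so the shift cannot be assigned to either feature alone. Nothing measured here gives a reason for the step.

The compounds shown leave open how a plain benzyl group with no chlorine, or a longer chain such as phenethyl, would behave on this nitrogen, and those two groups would help separate the effect of the halogens from that of the added carbon. They also leave open whether an amine or a carboxylic acid on the benzyl ring would move the number further, or in the opposite direction.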